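A Longer Side Chain on Compound 2

A few compounds are considered here, and "the series" means these few. Any claim that something is new, unique, unknown or untested is made for them only; others in the source may bear on it.

Measured in a functional assay on T-24 cells (Homo sapiens) for cytotoxicity, read by colorimetric assay and MTT assay; a lower number here means a stronger inhibitor, a higher number a weaker inhibitor:
- compound 1 `COc1cc(OC)c2cc(-c3ccccc3)c(O)nc2c1`: 10000 nM
- compound 2 `COc1ccc(-c2cc3c(OC)cc(OC)cc3n(CC#N)c2=O)cc1`: 10000 nM

Compound 2, at 10000 nM, stands level with compound 1, whose value is 10000 nM. Compound 3 `CCN(CC)C(=O)CCn1c(=O)c(-c2ccc(OC)cc2)cc2c(OC)cc(OC)cc21` has not yet been measured. It carries (diethylcarbamoyl)methyl in place of cyano on a saturated chain carbon bound to an aromatic nitrogen. For the measured compounds named here, no measured pair yet shows what a single change does in this assay, so no step beyond the scatter is expected, and no direction can be favoured. The estimated step is a 1.3-fold lower number from compound 2 to compound 3 (0.10 log units; within the scatter). For compound 3 the expected value is 8000 nM, within an estimated range of 3000 nM to 15000 nM.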

Compound 3, half-maximal inhibitory concentration: 10000 nM
The estimate for compound 3 lay 1.3-fold (0.10 log units) below the measured number; the measured number falls inside the stated range.
By their numbers in this assay, from the lowest: compounds 1, 2 and 3 (each within the scatter of the next).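

In this assay, replacing cyano with (diethylcarbamoyl)methyl gives no change at the digits printed from compound 2 to compound 3 (within the scatter). For the compounds shown here, this is the only single change that can be read so far, and it shows that 8 heavy atoms can enter where 2 leave without moving the number beyond the scatter. Nothing available explains this result.

On these data alone, whether an amine or a carboxylic acid on this chain would shift the number remains open. So does whether any change at this position can lower it.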